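Chloro to Trifluoromethyl on the Urea Aryl Ring

A few compounds are considered here, and "the series" means these few. Any claim that something is new, unique, unknown or untested is made for them only; others in the source may bear on it.

Compound 1 `COc1cc(-c2nn(-c3cccc(NC(=O)Nc4cc(C(F)(F)F)cc(C(F)(F)F)c4)c3)cc2-c2ccncc2)ccc1Cl` — 1710 nM
Compound 2 `COc1cc(-c2nn(-c3cccc(NC(=O)Nc4ccc(Cl)c(Cl)c4)c3)cc2-c2ccncc2)ccc1Cl` — 3080 nM
Compound 3 `O=C(Nc1cccc(-n2cc(-c3ccncc3)c(-c3ccc(Cl)c(O)c3)n2)c1)Nc1ccc(Cl)c(Cl)c1` — 8970 nM

Of the compounds shown here, three sharing the same core have been measured in a functional assay on SF-539 cells (Homo sapiens) for inhibition, read by sulforhodamine B assay, with a stated time of 48 h; a higher number here means a weaker inhibitor of growth, a lower number a stronger inhibitor of growth. Going by the values given here, compound 3 stands highest of the three; its nearest neighbour is compound 2, and the one measured step, a 2.9-fold higher number from compound 2 to compound 3 (0.46 log units; beyond the scatter), is a modest rise that lies beyond the scatter. Compound 1 and compound 2 differ in more than one place, so their values can only be set side by side: compound 1 gives 1710 nM and compound 2 gives 3080 nM.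

Compound 4 `O=C(Nc1cccc(-n2cc(-c3ccncc3)c(-c3ccc(Cl)c(O)c3)n2)c1)Nc1ccc(Cl)c(C(F)(F)F)c1` is the next step from compound 3. The change is trifluoromethyl in place of chloro on an aromatic carbon. Among the compounds with values here, none of the measured steps touches this position, so there is no directly bearing step; the side-by-side values of compound 1 and compound 2 show only that a ring carrying trifluoromethyl groups sits near one carrying chloro groups. The expectation for a 1.3-fold lower number from compound 3 to compound 4 (0.11 log units; within the scatter) is therefore a change not beyond the scatter. Compound 4 is expected to give about 7000 nM, within a range from 3000 nM to 18000 nM.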

Compound 4, concentration for total growth inhibition: 2390 nM
For compound 4 the middle estimate is 2.9-fold (0.47 log units) above the measured one; the whole stated range lies above it.
By their numbers in this assay, from the lowest: compounds 1, 4 and 2 (each within the scatter of the next); then compound 3.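

In this assay, the exchange of 3,4-dichlorophenyl for 4-chloro-3-(trifluoromethyl)phenyl gives a 3.8-fold lower number from compound 3 to compound 4 (0.57 log units; beyond the scatter), the first step measured at this position. Going by these compounds alone, it shows that trifluoromethyl in place of chloro, ortho to a chloro group, changes the number beyond the scatter in a compound carrying the free hydroxyl, whereas the only earlier step concerned a methyl on an oxygen on an aromatic ring. Nothing available here accounts for the size or direction of this step.

Going by these compounds, whether the same exchange would lower the number in compound 2, which keeps that methyl on the oxygen, remains open. On these data alone, it is also open whether a different group on this aromatic carbon, such as a nitrile or a dimethylamino group, would lower the number as trifluoromethyl does.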